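A few compounds are considered here, and "the series" means these few. Any claim that something is new, unique, unknown or untested is made for them only; others in the source may bear on it.

Measured in a functional assay on A-375 cells (Homo sapiens) for activation, with a stated time of 3 days; a lower number here means that less compound is needed, a higher number that more compound is needed for the effect:
- compound 1 `O=C(Nc1ccc(-c2cscn2)cc1)C1CCCN(Cc2ccc(F)c(F)c2)C1`: 1240 nM
- compound 2 `O=C(Nc1ccc(-c2cscn2)cc1)C1CCCN(Cc2cccc(F)c2)C1`: 5000 nM
- compound 3 `O=C(Nc1ccc(-c2cscn2)cc1)C1CCCN(Cc2cc(F)c(F)c(F)c2)C1`: 1260 nM

Compound 3 lies within the scatter of compound 1, and both have clearly lower numbers than compound 2. The step at issue leads to compound 4 `O=C(Nc1ccc(-c2cscn2)cc1)C1CCCN(Cc2ccc(Cl)c(Cl)c2)C1`: 3,4-dichlorophenyl in place of 3,4,5-trifluorophenyl on a saturated chain carbon bound to an amine nitrogen in a ring. In words, 3,4-dichlorophenyl stands in place of 3,4,5-trifluorophenyl on a saturated chain carbon bound to an amine nitrogen in a ring.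

Among the compounds with values here, three measured steps bear on it, though none of them involves chlorine. Removing one fluoro cost potency, with a 4.0-fold higher number from compound 1 to compound 2 (0.61 log units; beyond the scatter). Adding one made no measurable difference, with a 1.0-fold higher number from compound 1 to compound 3 (0.01 log units; within the scatter), and the full change of aromatic group gave a 4.0-fold lower number from compound 2 to compound 3 (0.60 log units; beyond the scatter). The two compounds with the lower numbers both have more than one halogen on the aromatic ring, so compound 4 is expected to stay near them in this assay, with only a small shift towards a lower number. The expected change is a 1.4-fold lower number from compound 3 to compound 4 (0.15 log units; within the scatter). For compound 4 the estimated value is 900 nM, with an expected range from 300 nM to 2700 nM.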

Compound 4, half-maximal effective concentration: 3000 nM
The estimate for compound 4 lay 3.3-fold (0.52 log units) below the measured number; the measured number lies above the stated range.
By their numbers in this assay, from the lowest: compounds 1 and 3 (each within the scatter of the next); then compounds 4 and 2 (each within the scatter of the next).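

In this assay, within the data shown here, more than one halogen on the aromatic ring does not by itself keep the number low: 3,4-dichlorophenyl, the first chlorine-bearing group at this place, gives a 2.4-fold higher number from compound 3 to compound 4 (0.38 log units; beyond the scatter), and the exchange of halogen alone, from 3,4-difluorophenyl, gives a 2.4-fold higher number from compound 1 to compound 4 (0.38 log units; beyond the scatter). With its two chlorines, the group also stays within the scatter of 3-fluorophenyl, with a 1.7-fold lower number from compound 2 to compound 4 (0.22 log units; within the scatter), so among these compounds the kind of halogen counts as well as the number of halogens. Nothing shown here gives a reason for the difference between chlorine and fluoro on this ring.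

The compounds shown leave open how a single chlorine, as in 3-chlorophenyl, would compare with the single fluoro of compound 2. They also leave open whether a methyl or methoxy group on the ring would fall with the fluoro or the chloro compounds.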